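Series notes: the step from compound 2 to compound 4

A few compounds are considered here, and "the series" means these few. Any claim that something is new, unique, unknown or untested is made for them only; others in the source may bear on it.

The three measured compounds share one core; compound 1 `O=C1/C(=C\c2ccccc2)S/C(=N/c2ccccc2)N1Cc1ccncc1`, compound 2 `O=C1/C(=C\c2ccc(O)cc2)S/C(=N/c2ccccc2)N1Cc1ccncc1` and compound 3 `CCOc1cc(/C=C2/S/C(=N/c3ccccc3)N(Cc3ccncc3)C2=O)ccc1O` differ only in the aryl group on the double-bonded chain carbon. In an ADME assay on HEK293 cells (Homo sapiens) for cytotoxicity, read by MTT assay, with a stated time of 48 h (a lower number here means a stronger inhibitor, a higher number a weaker inhibitor), compound 1 gives 64700 nM, compound 2 gives 142000 nM and compound 3 gives 46500 nM. Compound 2 stands highest of the three numbers, with compound 1 nearest and compound 3 furthest: a 2.2-fold higher number from compound 1 to compound 2 (0.34 log units; beyond the scatter), and a 3.1-fold lower number from compound 2 to compound 3 (0.48 log units; beyond the scatter). The step of a 1.4-fold lower number from compound 1 to compound 3 (0.14 log units; within the scatter) lies within the scatter.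

Compound 4 `COc1ccc(OC)c(/C=C2/S/C(=N/c3ccccc3)N(Cc3ccncc3)C2=O)c1` is not yet measured. Its change from compound 2: 2,5-dimethoxyphenyl in place of 4-hydroxyphenyl on a double-bonded chain carbon bound to a double-bonded ring carbon. Going by the values given here, two measured steps bear on it. The step of a 2.2-fold higher number from compound 1 to compound 2 (0.34 log units; beyond the scatter) shows that hydroxy in place of hydrogen on an aromatic carbon raised the number; compound 4 carries no hydroxy, so that step run backwards points lower. The step of a 3.1-fold lower number from compound 2 to compound 3 (0.48 log units; beyond the scatter) shows that ethoxy in place of hydrogen on an aromatic carbon lowered the number; compound 4 gains the methoxy groups of the 2,5-dimethoxyphenyl, which likewise points lower. For compound 4 the expected step in this assay is therefore modest and downward, a 2.8-fold lower number from compound 2 to compound 4 (0.45 log units; beyond the scatter). Compound 4 is estimated at 50000 nM, within the range 20000 nM to 130000 nM.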

Compound 4, half-maximal inhibitory concentration: 80100 nM
Beside the measured number, compound 4's estimate is 1.6-fold (0.20 log units) below it; measured number inside the range.
By their numbers in this assay, from the lowest: compounds 3, 1, 4 and 2 (each within the scatter of the next, the first and the last beyond it).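

At the double-bonded chain carbon, 2,5-dimethoxyphenyl does not separate compound 4 from any of the three earlier aryl variants in this assay: the steps are a 1.8-fold lower number from compound 2 to compound 4 (0.25 log units; within the scatter) and a 1.7-fold higher number from compound 3 to compound 4 (0.24 log units; within the scatter) and a 1.2-fold higher number from compound 1 to compound 4 (0.09 log units; within the scatter). The earlier set held one gap beyond the scatter, a 3.1-fold lower number from compound 2 to compound 3 (0.48 log units; beyond the scatter), and compound 4 falls within the scatter of both of its ends, so this change does not extend the spread seen so far. Going by these compounds alone, removing the hydroxy of compound 2 while adding two methoxy groups therefore gives no readable step here, unlike the single changes seen earlier.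

From the compounds shown here alone, whether an amine, a carboxylic acid or a chain longer than ethoxy on this aryl group would move the number beyond the scatter remains open. Nothing among the data explains why these aryl changes give steps of this size.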